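Swapping the aryl group on the shared core: chloro for fluoro

The source may hold more compounds than are shown below. What is called first, only, known or untested is meant among the compounds shown, and "the series" means these compounds.

In an ADME assay on Vero cells (Chlorocebus sabaeus) for cytotoxicity, read by neutral red uptake, tested at 1575 ug/mL (a lower number here means a stronger effect, a higher number a weaker effect of the compound at the concentration tested), compound 1 `O=C1CSC(c2ccc(O)cc2)N1CCN1CCCCC1` gives 12%. Compound 2 `O=C1CSC(c2cccc(F)c2)N1CCN1CCCCC1` gives 17% in this assay, and the two numbers lie within the usual scatter of each other, since the step was a number 5 percentage points higher from compound 1 to compound 2 (within the scatter). The next compound, compound 3 `O=C1CSC(c2ccc(Cl)cc2)N1CCN1CCCCC1`, has not yet been measured. It differs from compound 2 in one place: 4-chlorophenyl in place of 3-fluorophenyl on a saturated ring carbon. Among the compounds with values here, the only measured step that bears on this change is the earlier swap of one aryl group for another on the same saturated ring carbon, and it stayed within the scatter. On that basis the change from compound 2 to compound 3 is expected to bring no step beyond the scatter in this assay, that is a number 2 percentage points lower from compound 2 to compound 3 (within the scatter), because a number 5 percentage points higher from compound 1 to compound 2 (within the scatter) did not move the number. Compound 3 is therefore estimated to give 15%, with a range from 3% to 30%.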

Compound 3, a percentage reported as activity, at one concentration (the size of the read-out at that concentration, not a potency): 13%
Estimate against measurement, compound 3: 2 percentage points above; the measured number falls inside the stated range.
By their numbers in this assay, from the lowest: compounds 1, 3 and 2 (each within the scatter of the next).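

In this assay, the saturated ring carbon has now taken a third aryl group, and the change to 4-chlorophenyl gives a number 4 percentage points lower from compound 2 to compound 3 (within the scatter) and so adds another step within the scatter. The new comparison also changes only the group on the aromatic carbon: chloro in place of hydroxy gives a number 1 percentage points higher from compound 1 to compound 3 (within the scatter) and shows no separable change, whereas the earlier step exchanged 4-hydroxyphenyl for 3-fluorophenyl as whole groups. No measurement here accounts for how closely these numbers lie together.

The compounds shown leave open whether a phenyl group carrying an amine or a carboxylic acid, or a cyclohexyl group in place of the aryl group, would move the number beyond the scatter. They also leave open how chloro and fluoro compare on the same ring carbon, a comparison that 4-fluorophenyl would allow.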